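This account rests on a few compounds, and the source may have more. Where it says the series, first, only, none or still open, it means among the compounds named here.

Compound 2, with the structure `COc1ccc(C2CC(c3cc(Cl)c(C)cc3O)=NN2c2ccc(S(N)(=O)=O)cc2)cc1OC`, is measured in a functional assay on SK-MEL-2 cells (Homo sapiens) for antiproliferative activity, with a stated time of 48 h (a lower number here means a stronger inhibitor of growth, a higher number a weaker inhibitor of growth), where it gives 32700 nM. Among the two numbers recorded it stands highest, yet its only neighbour, compound 1 with the structure `Cc1cc(O)c(C2=NN(c3ccc(S(N)(=O)=O)cc3)C(c3ccccc3O)C2)cc1Cl`, gives 27200 nM in this assay, and the two cannot be told apart. Among the measured compounds shown here, the one measured step, a 1.2-fold higher number from compound 1 to compound 2 (0.08 log units; within the scatter), comes from a change at the same saturated ring carbon and did not move the number beyond the scatter.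

Compound 3, with the structure `COc1ccc(C2CC(c3cc(Cl)c(C)cc3O)=NN2c2ccc(S(N)(=O)=O)cc2)c(OC)c1OC`, has not yet been measured. It differs from compound 2 by methoxy in place of hydrogen on an aromatic carbon. For the measured compounds named here, no measured step adds a methoxy group to this aryl ring, so the closest guide is the exchange of the whole aryl group from compound 1 to compound 2, which left the number where it was. On that basis a further methoxy group is expected to produce no step beyond the scatter, and a 1.0-fold higher number from compound 2 to compound 3 (0.00 log units; within the scatter) is the estimate. For compound 3 the expected value in this assay is 33000 nM, with a range from 12000 nM to 90000 nM.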

Compound 3, concentration for total growth inhibition: 12000 nM
Estimate against measurement, compound 3: 2.8-fold (0.44 log units) above, and the stated range covers the measured number.
By their numbers in this assay, from the lowest: compound 3; then compounds 1 and 2 (each within the scatter of the next).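

Adding methoxy on an aromatic carbon, ortho to a large group and ortho to a methoxy group, is the first change here to move the number beyond the scatter in this assay (the step is a 2.7-fold lower number from compound 2 to compound 3 (0.44 log units; beyond the scatter)), so this aryl group is not as indifferent to change as the earlier pair suggested. The exchange of 2-hydroxyphenyl for 2,3,4-trimethoxyphenyl likewise lies beyond the scatter (the step is a 2.3-fold lower number from compound 1 to compound 3 (0.36 log units; beyond the scatter)), whereas the exchange for 3,4-dimethoxyphenyl stayed within it (the step is a 1.2-fold higher number from compound 1 to compound 2 (0.08 log units; within the scatter)), so among these three compounds the shift appears only when the added methoxy group is present. Nothing available explains why this added group shifts the number.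

The three compounds cannot tell whether the shift depends on this particular aromatic carbon or would follow a methoxy group placed elsewhere on the ring, or whether that methoxy group would have the same effect without the 3,4-dimethoxy pattern. They also leave open whether another group at the same carbon, such as an amine, a fluorine atom or a longer ether chain like ethoxy, would lower the number further, keep it level or raise it.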